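Aryl ether in place of the octyl chain on the core

The source may report more compounds than this note shows. Statements on the series, on what has been measured and on what is new or still open speak of the compounds shown alone.

Measured so far:
compound 1 `CCCCCCCCOC1CC(=O)Nc2c1c(C)nn2-c1ncnc2nc[nH]c12` gives 8 nM in a functional assay on HEK293 cells for agonist activity at G-protein coupled receptor 39 (Homo sapiens), read by scintillation proximity assay and inositol phosphate accumulation, with a stated time of 75 min, in the presence of a further agent that is not named here; on this read-out higher numbers stand for an effect only at larger amounts of compound and lower numbers for an effect already at smaller amounts
compound 2 `Cc1nn(-c2ncnc3nc[nH]c23)c2c1C(NC(=O)Cc1cccs1)CC(=O)N2` gives 3 nM in this assay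
compound 3 `Cc1nn(-c2ncnc3nc[nH]c23)c2c1C(NC(=O)c1ccccc1)CC(=O)N2` gives 3 nM in this assay

Compound 1 stands at the highest number of the three, with a 2.7-fold lower number from compound 1 to compound 2 (0.43 log units; beyond the scatter) and a 2.7-fold lower number from compound 1 to compound 3 (0.43 log units; beyond the scatter); between compounds 2 and 3 there is no change at the digits printed from compound 2 to compound 3 (within the scatter).

Compound 4 `COc1ccc(CCOC2CC(=O)Nc3c2c(C)nn3-c2ncnc3nc[nH]c23)cc1` keeps the ether of compound 1 and shows (4-methoxyphenyl in place of hexyl on a saturated chain carbon, two bonds along the chain from an oxygen on a saturated carbon). Among the measured compounds shown here, no measured step alters only the chain end of the ether; the two steps from compound 1 exchange the whole octyloxy group and are modest. The change to compound 4 is therefore expected to give a small step, if any, toward a lower number, a 1.3-fold lower number from compound 1 to compound 4 (0.12 log units; within the scatter). For compound 4 the estimate in this assay is 6 nM, with a range from 2 nM to 20 nM.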

Compound 4, half-maximal effective concentration: 2 nM
Estimate against measurement, compound 4: 3.0-fold (0.48 log units) above; the range from low to high includes it.
By their numbers in this assay, from the lowest: compounds 4, 2 and 3 (each within the scatter of the next); then compound 1.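

Compound 1's earlier steps exchanged the whole octyloxy group, whereas this one leaves the ether in place and alters only the chain end. It gives a 4.0-fold lower number from compound 1 to compound 4 (0.60 log units; beyond the scatter) and shows that the chain end alone can move the number beyond the scatter. It also shows that a chain end carrying an aromatic ring and a methoxy group is accepted here, though no evidence at hand accounts for the step.

The compounds shown do not separate the contribution of the methoxy group from that of the phenyl ring. Going by these compounds, a plain phenyl, a pyridine ring or a carboxylic acid at the chain end remains open, as does a longer link to the ring.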